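The source may hold more compounds than are shown below. What is called first, only, known or untested is meant among the compounds shown, and "the series" means these compounds.

Measured compounds:
compound 1, `CC[C@@H](C)[C@H](NC(=O)c1ccc(Oc2nc3ccccc3nc2C)cc1)C(=O)OC`, > 50000 nM;
compound 2, `Cc1nc2ccccc2nc1Oc1ccc(C(=O)N[C@@H](C)C(=O)O)cc1`, 22300 nM;
compound 3, `CCCCCCCCCCCCNc1nc2ccccc2nc1Oc1ccc(C(=O)N[C@H](C(=O)OC)[C@H](C)CC)cc1`, 40300 nM.

In a functional assay on HeLa cells (Homo sapiens) for antiproliferative activity, read by MTT assay, with a stated time of 48 h (on this read-out lower numbers stand for stronger inhibition and higher numbers for weaker inhibition), compound 1 gives > 50000 nM, which is a limit of the assay and not a number: the limit of > 50000 nM in this assay, at which 1 of the 3 values shown sits. Compound 2 gives 22300 nM in this assay. The change from compound 1 to compound 2 is 1-carboxyethyl in place of 1-(methoxycarbonyl)-2-methylbutyl on an amide-type nitrogen, and it brought an at least 2.2-fold lower number from compound 1 to compound 2 (0.35 log units; beyond the scatter). Compound 3 gives 40300 nM in this assay; the difference between its core and the core of compound 1 is not broken down here, and its value and that of compound 2 lie within the usual scatter of each other.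

Compound 4, `CCCCCCCCCCCCNc1nc2ccccc2nc1Oc1ccc(C(=O)N[C@@H](C)C(=O)O)cc1`, has not yet been measured in this assay. It differs from compound 3 by 1-carboxyethyl in place of 1-(methoxycarbonyl)-2-methylbutyl on an amide-type nitrogen, at the same place as the change from compound 1 to compound 2, so this is the same change made on the core of compound 3. Because that change gave an at least 2.2-fold lower number from compound 1 to compound 2 (0.35 log units; beyond the scatter), a step of similar size is expected here, with more uncertainty since the starting value of compound 1 is only a limit. The expected step is a 2.2-fold lower number from compound 3 to compound 4 (0.35 log units; beyond the scatter). For compound 4 the estimate in this assay is 18000 nM, between 6000 nM and 50000 nM.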

Compound 4, half-maximal inhibitory concentration: 6240 nM
For compound 4 the middle estimate is 2.9-fold (0.46 log units) above the measured one; measured number inside the range.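

In this assay the exchange of 1-(methoxycarbonyl)-2-methylbutyl for 1-carboxyethyl on the amide-type nitrogen brought a 6.5-fold lower number from compound 3 to compound 4 (0.81 log units; beyond the scatter). The number fell on both cores, so the direction of the change carried over from the core of compound 1 to the core of compound 3, and the two steps compare as follows: the same change on two cores in this assay, an at least 2.2-fold lower number (0.35 log units; beyond the scatter) from compound 1 to compound 2 and a 6.5-fold lower number (0.81 log units; beyond the scatter) from compound 3 to compound 4; the limit leaves it open whether they differ. Compound 1 stands at a limit of the assay and not at a number, so this pair of steps does not show that the size of the change carries over from one core to the other: the limit of > 50000 nM in this assay, at which 1 of the 4 values shown sits.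

The compounds shown leave open which part of the exchange goes with the step, the carboxylic acid in place of the methyl ester or the smaller group; a methyl ester of the 1-carboxyethyl group and a carboxylic acid that keeps the 2-methylbutyl side chain would separate the two. Also open, as far as these compounds go, is how the step would read on a core with a shorter chain on its amine.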